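Swapping a Chlorophenyl Arm for Indole on the Hydrazone

A few compounds are considered here, and "the series" means these few. Any claim that something is new, unique, unknown or untested is made for them only; others in the source may bear on it.

Of the compounds shown here, three sharing one core have been tested in a functional assay on MCF7 cells (Homo sapiens) for antiproliferative activity, read by MTT assay, with a stated time of 72 h; a higher number here means a weaker inhibitor, a lower number a stronger inhibitor. Compound 1 `CCCSc1nc(N/N=C/c2cccnc2)c2nnn(Cc3ccccc3)c2n1` gives 58700 nM. Compound 2 `CCCSc1nc(N/N=C(\C)c2ccc(O)cc2)c2nnn(Cc3ccccc3)c2n1` gives 21600 nM, a step of a 2.7-fold lower number from compound 1 to compound 2 (0.43 log units; beyond the scatter). For compound 3 `CCCSc1nc(N/N=C/c2ccc(Cl)cc2)c2nnn(Cc3ccccc3)c2n1` the read-out is only a limit, > 64000 nM. Compound 3 therefore sits at the edge of what the assay reports: the step of an at least 1.0-fold higher number from compound 1 to compound 3 (0.03 log units; that floor lies within the scatter) leaves its gap from compound 1 unsettled, while an at least 2.9-fold higher number from compound 2 to compound 3 (0.47 log units; beyond the scatter) does separate it from compound 2. Compound 4 `CCCSc1nc(N/N=C/c2c[nH]c3ccccc23)c2nnn(Cc3ccccc3)c2n1` differs from compound 3 by 1H-indol-3-yl in place of 4-chlorophenyl on a carbon with a double bond to nitrogen. Among the measured compounds shown here, of the measured steps, the one from compound 1 to compound 3 also exchanged the aryl group on the carbon double-bonded to nitrogen and stayed within the scatter, so only a small move is anticipated. The expected shift is an at least 1.4-fold lower number from compound 3 to compound 4 (0.15 log units; that floor lies within the scatter). In this assay compound 4 is estimated at 45000 nM, within 15000 nM to 130000 nM.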

Compound 4, half-maximal inhibitory concentration: 9010 nM
Beside the measured number, compound 4's estimate is 5.0-fold (0.70 log units) above it; measured number below the stated range.
By their numbers in this assay, from the lowest: compound 4; then compound 2; then compound 1. At a limit, above all of these: compound 3.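

The earlier aryl swap at this place could not be told from the scatter, but 1H-indol-3-yl on the carbon with a double bond to nitrogen brings an at least 7.1-fold lower number from compound 3 to compound 4 (0.85 log units; beyond the scatter), and also a 6.5-fold lower number from compound 1 to compound 4 (0.81 log units; beyond the scatter). Of the three groups compared here, 1H-indol-3-yl gives the lowest number. Compound 3 gives only a limit, so its step is a floor: the limit of > 64000 nM in this assay, at which 1 of the 4 values shown sits.

On these data alone, what stays open is whether the gain follows the hydrogen-bond donor or the second ring, since 1H-indol-3-yl brings both. A naphthyl group on this carbon would separate the two.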